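A few compounds are considered here, and "the series" means these few. Any claim that something is new, unique, unknown or untested is made for them only; others in the source may bear on it.

Three compounds share one core and differ only in the group carried on a five-membered aromatic ring with 3 nitrogen. Compound 1 `O=c1cc(Cn2cc(C3CC3)nn2)c2ccc(O)cc2o1` bears a cyclopropyl there, compound 2 `O=c1cc(Cn2cc(CCCCl)nn2)c2ccc(O)cc2o1` a 3-chloropropyl, and compound 3 `O=c1cc(Cn2cc(CCc3ccccc3)nn2)c2ccc(O)cc2o1` a phenethyl. In a functional assay on A549 cells (Homo sapiens) for inhibition, read by MTT assay, with a stated time of 72 h (on this read-out lower numbers stand for stronger inhibition and higher numbers for weaker inhibition), compound 1 gives 91700 nM, compound 2 gives 30100 nM, and compound 3 gives 24800 nM. Compound 2 therefore stands second highest of the three, and its value and that of compound 3 lie within the usual scatter of each other.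

Compound 4 `O=c1cc(Cn2cc(-c3cc(F)cc(F)c3)nn2)c2ccc(O)cc2o1` is not yet measured. Relative to compound 2 the change is 3,5-difluorophenyl in place of 3-chloropropyl on an aromatic carbon.

Among the compounds with values here, two measured steps bear on it. Replacing the small cyclopropyl with a longer chain gave a 3.0-fold lower number from compound 1 to compound 2 (0.48 log units; beyond the scatter) and a 3.7-fold lower number from compound 1 to compound 3 (0.57 log units; beyond the scatter), while swapping the chain end gave only a 1.2-fold lower number from compound 2 to compound 3 (0.08 log units; within the scatter). Moving a ring directly onto the aromatic carbon is untested, so only a small step is expected, a 1.5-fold lower number from compound 2 to compound 4 (0.18 log units; within the scatter). Compound 4 is estimated at 20000 nM, within a range from 7000 nM to 60000 nM.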

Compound 4, half-maximal inhibitory concentration: 21100 nM
Compound 4: middle estimate off by 1.1-fold (0.02 log units), on the low side; measured number inside the range.
By their numbers in this assay, from the lowest: compounds 4, 3 and 2 (each within the scatter of the next); then compound 1.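

A six-membered aromatic ring set directly on the aromatic carbon does as well here as a chain: this assay shows a 1.4-fold lower number from compound 2 to compound 4 (0.15 log units; within the scatter) and a 1.2-fold lower number from compound 3 to compound 4 (0.07 log units; within the scatter) so a chain is not needed at this position to reach this level of inhibition. The 3,5-difluorophenyl also separates from cyclopropyl, with a 4.3-fold lower number from compound 1 to compound 4 (0.64 log units; beyond the scatter) and this leaves compound 1 alone apart from the other three. No measurement here explains why such different groups read alike.

Still open, on these data alone, is whether a plain phenyl would match the 3,5-difluorophenyl, which would show whether the two fluorines contribute anything. Also open, as far as these compounds go, is how this position responds to a group of another kind, such as an amine or a carboxylic acid.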